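Aryl amine variation on the shared core: compound 4

A few compounds are considered here, and "the series" means these few. Any claim that something is new, unique, unknown or untested is made for them only; others in the source may bear on it.

Compound 1 `CCS(=O)(=O)Nc1cc(-c2ccc3ncnc(Nc4ccc(F)cc4)c3c2)cnc1OC` gives 3120 nM in a functional assay on BT-549 cells (Homo sapiens) for cytotoxicity, read by sulforhodamine B assay, with a stated time of 72 h; a lower number here means a stronger inhibitor, a higher number a weaker inhibitor. Compound 2 `CCS(=O)(=O)Nc1cc(-c2ccc3ncnc(Nc4ccc(OC)c(OC)c4)c3c2)cnc1OC` gives 2590 nM, and compound 3 `CCS(=O)(=O)Nc1cc(-c2ccc3ncnc(Nc4ccc(OC)c(Cl)c4)c3c2)cnc1OC` gives 2470 nM. The steps of a 1.2-fold lower number from compound 1 to compound 2 (0.08 log units; within the scatter), a 1.3-fold lower number from compound 1 to compound 3 (0.10 log units; within the scatter) and a 1.0-fold lower number from compound 2 to compound 3 (0.02 log units; within the scatter) all fall within the scatter, so compound 3 is not separated from the other two. Compound 4 `CCS(=O)(=O)Nc1cc(-c2ccc3ncnc(Nc4ccc(OC)nc4)c3c2)cnc1OC` differs from compound 3 by 6-methoxypyridin-3-yl in place of 3-chloro-4-methoxyphenyl on a nitrogen on an aromatic ring. All three measured steps change the same aryl group on this nitrogen and none moves the number beyond the scatter, so the step of a 1.1-fold higher number from compound 3 to compound 4 (0.02 log units; within the scatter) is expected to stay within the scatter as well. Compound 4 is therefore estimated at 2600 nM, with a range of 1200 nM to 5800 nM.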

Compound 4, half-maximal inhibitory concentration: 3490 nM
Compound 4: the middle estimate sits 1.3-fold (0.13 log units) below what was measured; low and high end bracket the measured number.
By their numbers in this assay, from the lowest: compounds 3, 2, 1 and 4 (each within the scatter of the next).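

For the compounds shown here, putting 6-methoxypyridin-3-yl on this nitrogen brings a ring with a hetero atom to a position that had so far carried only carbon aromatic rings, yet every step stays within the scatter (a 1.4-fold higher number from compound 3 to compound 4 (0.15 log units; within the scatter)), (a 1.3-fold higher number from compound 2 to compound 4 (0.13 log units; within the scatter)) and (a 1.1-fold higher number from compound 1 to compound 4 (0.05 log units; within the scatter)). All four aryl groups on this nitrogen are therefore not separated from one another, and the change of ring atom leaves the number as flat as the earlier changes did. Nothing available accounts for this flat response.

Going by these compounds, whether an amine or a carboxylic acid on this aryl ring, or a longer chain in place of the methoxy, would move the number beyond the scatter remains open.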